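A few compounds are considered here, and "the series" means these few. Any claim that something is new, unique, unknown or untested is made for them only; others in the source may bear on it.

Compound 1 `C=C(c1ccccc1)c1ccc(N(Cc2cccnc2)S(=O)(=O)CC)cc1` is the weaker of the two measured compounds. In an assay on isolated protein with metabotropic glutamate receptor 2 (Homo sapiens) as the target (on this read-out higher numbers stand for an effect only at larger amounts of compound and lower numbers for an effect already at smaller amounts), compound 1 gives 780 nM, the highest of the two numbers at hand; compound 2 `C=C(c1ccccc1)c1cccc(N(Cc2cccnc2)S(=O)(=O)CC)c1` gives 200 nM in this assay, a gap that lies beyond the scatter. Compound 3 `CCS(=O)(=O)N(Cc1cccnc1)c1ccc(C(F)c2ccccc2)cc1` has not yet been measured. It differs from compound 1 in one place: fluoro(phenyl)methyl in place of 1-phenylethenyl on an aromatic carbon. For the measured compounds named here, no measured pair in this set carries the same change, so nothing here shows how this assay answers to it. As the leaving and entering groups are alike in heavy-atom count and ring count, and only the double bond outside aromatic rings is given up, a step within or barely beyond the scatter is expected, with no firm direction. For compound 3 an estimate of 600 nM in this assay is given, within 200 nM to 2000 nM. The step of a 1.3-fold lower number from compound 1 to compound 3 (0.11 log units; within the scatter) is expected to be small.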

Compound 3, half-maximal effective concentration: > 30000 nM
Compound 3: no number, only a limit; the forecaster's own chance of this, stated with the estimate: 5%; middle value at least 50-fold (1.69 log units) away from the limit.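

In this assay, compound 3 gives only a limit, > 30000 nM, not a number. Fluoro(phenyl)methyl in place of 1-phenylethenyl on this aromatic carbon, para to a large group, gives an at least 38-fold higher number from compound 1 to compound 3 (1.58 log units; beyond the scatter), so this position answers sharply to a change that keeps the heavy-atom count and the ring count and gives up the double bond outside aromatic rings. Only the lower bound of this step can be read, because compound 3 carries a limit rather than a number: the limit of > 30000 nM in this assay, at which 1 of the 3 values shown sits.

On these data alone, it remains open whether the fluorine or the loss of the double bond accounts for the step, and what a plain benzyl group or a benzoyl group would do at this place. Also open, as far as these compounds go, is how the same change would read on compound 2.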